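A few compounds are considered here, and "the series" means these few. Any claim that something is new, unique, unknown or untested is made for them only; others in the source may bear on it.

Compound 3 `CCOC(=O)C1=Cc2ccccc2OC1(OCc1cn(-c2ccccc2)nn1)C(F)(F)F` carries a phenyl on the ring nitrogen of its five-membered ring with three nitrogens. In a functional assay on MCF7 cells (Homo sapiens) for inhibition, read by MTT assay, with a stated time of 24 h (a higher number here means a weaker inhibitor, a lower number a stronger inhibitor), compound 3 gives > 150000 nM, which is a limit of the assay and not a number. Compound 1 `CCOC(=O)C1=Cc2ccccc2OC1(OCc1cn(-c2cccc(OC)c2)nn1)C(F)(F)F` likewise reaches only a limit in this assay, at > 150000 nM. Compound 2 `CCOC(=O)C1=Cc2ccccc2OC1(OCc1cn(CC(=O)NC2CCCCC2)nn1)C(F)(F)F`, with a (cyclohexylcarbamoyl)methyl in place of the aryl group, gives 12100 nM in this assay, so that an at least 12-fold lower number from compound 1 to compound 2 (1.09 log units; beyond the scatter) and an at least 12-fold higher number from compound 2 to compound 3 (1.09 log units; beyond the scatter). The step from compound 1 to compound 3 cannot be read, since (the limit of > 150000 nM in this assay, at which 2 of the 3 values shown sit). Compound 4 `CCOC(=O)C1=Cc2ccccc2OC1(OCc1cn(-c2ccc(F)c([N+](=O)[O-])c2)nn1)C(F)(F)F` differs from compound 3 in one place: 4-fluoro-3-nitrophenyl in place of phenyl on an aromatic nitrogen. Within the data shown here, no measured step changes substituents on an aryl group attached to this ring nitrogen in a readable way; both aryl compounds shown sit at the limit. Compound 4 is therefore expected to stay near that limit, with a number no higher from compound 3 to compound 4 (the limit leaves the size open) reckoned as no readable change, and its value is estimated at 150000 nM, between 40000 nM and 600000 nM.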

Compound 4, half-maximal inhibitory concentration: 16200 nM
For compound 4 the middle estimate is 9.3-fold (0.97 log units) above the measured one; the measured number lies below the stated range.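

The aryl group on the ring nitrogen does not by itself hold the read-out at the limit: in this assay there is an at least 9.2-fold lower number from compound 3 to compound 4 (0.96 log units; beyond the scatter) and also an at least 9.2-fold lower number from compound 1 to compound 4 (0.96 log units; beyond the scatter). Substituents on this aryl group can therefore shift the read-out, which no readable step among the earlier compounds showed, and there is a 1.3-fold higher number from compound 2 to compound 4 (0.13 log units; within the scatter), so compound 4 cannot be told apart from compound 2. The step between compound 1 and compound 3 still cannot be read: the limit of > 150000 nM in this assay, at which 2 of the 4 values shown sit.

Since the fluoro and nitro substituents enter together in compound 4, the compounds shown do not tell which of them accounts for the step. As far as these compounds go, how an aryl group bearing an amine or a carboxylic acid instead of the nitro group would read in this assay also remains open.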